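The compounds below may be only part of what the source reports. "The series", "measured", "known", "first", "only" and "open" are said of these compounds alone.

Measured so far in a functional assay on NCI-H460 cells (Homo sapiens) for cytotoxicity, read by MTT assay, with a stated time of 48 h; a higher number here means a weaker inhibitor, a lower number a stronger inhibitor:
- Compound 1 `C=C1C(=O)O[C@H]2CC3=C[C@H](C/C(C)=C/[C@@H](OC(=O)c4ccc(C(C)=O)cc4)[C@H]12)OC3=O`: 2200 nM
- Compound 2 `C=C1C(=O)O[C@H]2CC3=C[C@H](C/C(C)=C/[C@@H](OC(=O)/C=C/c4cccc(OC)c4)[C@H]12)OC3=O`: > 10000 nM (a limit of the assay, not a number)

Compound 2 has no exact value and stands only at a limit: the limit of > 10000 nM in this assay, at which 1 of the 2 values shown sits. Moving on to compound 3 `C=C1C(=O)O[C@H]2CC3=C[C@H](C/C(C)=C/[C@@H](OC(=O)C4CCC(F)(F)CC4)[C@H]12)OC3=O` brings one change: 4,4-difluorocyclohexyl in place of 2-(3-methoxyphenyl)ethenyl on a carbonyl carbon. In words, 4,4-difluorocyclohexyl takes the place of 2-(3-methoxyphenyl)ethenyl on a carbonyl carbon.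

Among the measured compounds shown here, the only measured step, an at least 4.5-fold higher number from compound 1 to compound 2 (0.65 log units; beyond the scatter), also changes the group on this carbonyl carbon and lies beyond the scatter. The group here can therefore shift the result in this assay. For the measured compounds named here, no measured compound carries a non-aromatic ring at this place, so the direction is only a cautious guess. Compound 1 gives a real number at 2200 nM, which leaves room for a modest move to a lower number. The expected change is an at least 2.0-fold lower number from compound 2 to compound 3 (0.30 log units; that floor lies within the scatter). For compound 3 the estimate is 5000 nM, with an expected range from 1500 nM to 12000 nM.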

Compound 3, half-maximal inhibitory concentration: > 10000 nM
Compound 3 ended at the assay's limit (the forecaster's own chance of this, stated with the estimate: 25%); at least 2.0-fold (0.30 log units) between middle value and limit.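

Compound 3 gives > 10000 nM in this assay, which is a limit of the assay and not a number. With 4,4-difluorocyclohexyl in place of 4-acetylphenyl on this carbonyl carbon, the result is an at least 4.5-fold higher number from compound 1 to compound 3 (0.65 log units; beyond the scatter), so a non-aromatic ring, like the 2-(3-methoxyphenyl)ethenyl group before it, gives no measurable value here, and of the three groups shown only 4-acetylphenyl does. The step between compound 2 and compound 3 cannot be read, because both rest on the same limit: the limit of > 10000 nM in this assay, at which 2 of the 3 values shown sit.

Still open, on these data alone, is whether the result of compound 1 depends on its acetyl group or on the aromatic ring that carries it. A plain phenyl ring, or a phenyl ring bearing an amine or a carboxylic acid in place of acetyl, would help separate the two.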